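From a Urea to a Benzamide on the Shared Core

A few compounds are considered here, and "the series" means these few. Any claim that something is new, unique, unknown or untested is made for them only; others in the source may bear on it.

Compound 1, `COc1cc(-c2nn(-c3cccc(NC(=O)Nc4ccc(Cl)c(Cl)c4)c3)cc2-c2ccncc2)ccc1Cl`: in a functional assay on U-251 cells (Homo sapiens) for inhibition, read by sulforhodamine B assay, with a stated time of 48 h (on this read-out lower numbers stand for higher toxicity in this test and higher numbers for lower toxicity in this test), compound 1 reaches only the limit > 50000 nM.
Compound 2, `O=C(Nc1cccc(-n2cc(-c3ccncc3)c(-c3ccc(Cl)c(O)c3)n2)c1)Nc1ccc(Cl)c(Cl)c1`: in this assay compound 2 reaches only the limit > 32500 nM.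
Compound 3, `O=C(Nc1cccc(-n2cc(-c3ccncc3)c(-c3ccc(Cl)c(O)c3)n2)c1)Nc1cc(C(F)(F)F)cc(C(F)(F)F)c1`: in this assay compound 3 gives 2800 nM.

Compound 1 stands at a limit of this assay, so no number is known for it. Compound 2 also stands at a limit. Within the data shown here, the one single-point step, hydrogen in place of methyl on an oxygen on an aromatic ring, is therefore a step that the two limits leave unreadable from compound 1 to compound 2; both ends sit at limits, the limit of > 50000 nM in this assay, at which 1 of the 3 values shown sits, and (the limit of > 32500 nM in this assay, at which 1 of the 3 values shown sits). Among the measured compounds shown here, compound 3 is the only member of the set that returns a number, and it differs from compound 2 at the urea end.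

Compound 4, `COc1cc(-c2nn(-c3cccc(NC(=O)c4ccccc4)c3)cc2-c2ccncc2)ccc1Cl`, changes compound 1 by phenyl in place of (3,4-dichlorophenyl)amino on a carbonyl carbon: the urea becomes a benzamide. For the measured compounds named here, no measured step covers this change. The expectation for compound 4 rests on compound 1 sitting at the limit > 50000 nM, and compound 4 is expected to stay at a limit as well. The step from compound 1 to compound 4 is estimated as a step that the limit leaves unreadable from compound 1 to compound 4. For compound 4 the estimate in this assay is 70000 nM, within a range of 30000 nM to 200000 nM.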

Compound 4, concentration lethal to 50% of the cells: > 100000 nM
Compound 4: a limit, no number; the forecaster's own chance of this, stated with the estimate: 80%; at least 1.4-fold (0.15 log units) between middle value and limit.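

In this assay compound 4 gives only the limit > 100000 nM and no number. Compound 1 also stands at a limit, so no step can be read between compound 1 and compound 4. The compounds shown leave open whether the urea or the benzamide on the shared core is the more toxic in this test.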